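A halogen swap at the limit of the assay

The compounds below may be only part of what the source reports. "The series", "measured", "known", "first", "only" and "open" are said of these compounds alone.

In a functional assay on NCI/ADR-RES cells (Homo sapiens) for inhibition (on this read-out higher numbers stand for weaker inhibition of growth and lower numbers for stronger inhibition of growth), compound 1 (`O=S(=O)(/C=C/c1ccc(Cl)cc1Cl)Cc1ccc(Nc2ncnc3ccccc23)cc1`) gives 5000 nM. Compound 2 (`O=S(=O)(/C=C/c1ccc(Cl)cc1Cl)Cc1ccc(Nc2ncnc3cc(Cl)ccc23)cc1`) stands at > 100000 nM in this assay, and this is a limit of the assay, not a number. Going by the values given here, the only measured step, an at least 20-fold higher number from compound 1 to compound 2 (1.30 log units; beyond the scatter), is large and put chloro in place of hydrogen on an aromatic carbon of the shared core. Compound 3 (`O=S(=O)(/C=C/c1ccc(F)cc1Cl)Cc1ccc(Nc2ncnc3cc(Cl)ccc23)cc1`) differs from compound 2 elsewhere: fluoro in place of chloro on an aromatic carbon. Here fluoro stands in place of chloro, turning 2,4-dichlorophenyl into 2-chloro-4-fluorophenyl. Among the compounds with values here, no measured step makes this exchange, so that large step offers only a loose guide and gives no direction. The expected step is a number no higher from compound 2 to compound 3 (the limit leaves the size open), with none expected beyond the scatter. Compound 3 is estimated at 100000 nM, with an expected range from 20000 nM to 200000 nM.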

Compound 3, concentration for 50% growth inhibition: > 100000 nM
Compound 3 gave a limit, no number (the forecaster's own chance of this, stated with the estimate: 65%); the middle value lies on the limit itself.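

Compound 2 and compound 3 both stand at a limit of the assay rather than at a number, so no step can be read between them: the limit of > 100000 nM in this assay, at which 2 of the 3 values shown sit. In this assay the compounds shown leave open whether fluoro in place of chloro changes growth inhibition at all.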